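This account rests on a few compounds, and the source may have more. Where it says the series, first, only, none or still open, it means among the compounds named here.

In a functional assay on MKN-45 cells (Homo sapiens) for cytotoxicity, read by MTT assay, with a stated time of 72 h (a lower number here means a stronger inhibitor, a higher number a weaker inhibitor), three compounds have been characterised. For the measured compounds named here, compound 1 `Fc1cc(Nc2cc(Nc3ccc(Cl)cc3)ncn2)ccc1Oc1ccncc1-c1cccnc1` gives 240 nM, and compound 2 `Fc1cc(Nc2cc(Nc3cccc(Cl)c3)ncn2)ccc1Oc1ccncc1-c1cccnc1` gives 30 nM; the single change between them, a 3-chlorophenyl in place of a 4-chlorophenyl on a nitrogen on an aromatic ring, produced an 8.0-fold lower number from compound 1 to compound 2 (0.90 log units; beyond the scatter). Compound 3 `Cn1c(=O)c(C(=O)Nc2ccc(Oc3ccncc3-c3cccnc3)c(F)c2)nn(-c2ccccc2F)c1=O`, built on a different core, gives 4780 nM, the highest of the three numbers: its gap to compound 1 and its larger gap to compound 2 both lie beyond the scatter.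

Compound 4 `Cn1c(=O)c(C(=O)Nc2ccc(Oc3ccncc3-c3cccnc3)c(F)c2)nn(-c2cccc(C(F)(F)F)c2)c1=O` is the next member. It differs from compound 3 by 3-(trifluoromethyl)phenyl in place of 2-fluorophenyl on an aromatic nitrogen. Going by the values given here, the only measured step that bears on this kind of change is the one from compound 1 to compound 2, where moving a substituent around a phenyl on a nitrogen gave a modest step; here the ring and its substituent both change, on a different core, so the direction is not settled. The step is therefore expected to be small, at most modest, and for compound 4 an estimate of 4000 nM with a range of 1500 nM to 12000 nM is expected, which would mean a 1.2-fold lower number from compound 3 to compound 4 (0.08 log units; within the scatter).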

Compound 4, half-maximal inhibitory concentration: 1950 nM
The estimate for compound 4 lay 2.1-fold (0.31 log units) above the measured number; measured number inside the range.
By their numbers in this assay, from the lowest: compound 2; then compound 1; then compound 4; then compound 3.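

This position on the aromatic nitrogen responds to the group it carries in this assay: 3-(trifluoromethyl)phenyl in place of 2-fluorophenyl gave a 2.5-fold lower number from compound 3 to compound 4 (0.39 log units; beyond the scatter), a modest step but one beyond the scatter. For the compounds shown here, the earlier compounds showed a change to a substituted phenyl on a nitrogen only on the core of compound 1, so this is the first such step on the second core, and there the substituent and its place on the phenyl changed together. No measurement shown accounts for this step.

The compounds shown leave open whether the lower number follows from the trifluoromethyl group itself or from its place on the phenyl. They also leave open how this position would respond to a phenyl bearing a methoxy group or an amine, or to a cyclohexyl group in place of the phenyl.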